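The compounds below may be only part of what the source reports. "The series", "measured", "known", "first", "only" and "open" are said of these compounds alone.

Measured in a functional assay on HCT-116 cells (Homo sapiens) for inhibition, read by MTT assay, with a stated time of 48 h; a higher number here means a weaker inhibitor, a lower number a stronger inhibitor:
Compound 1 `COc1ccc(CN(C(=O)C[Se]C#N)c2cc(OC)c(OC)c(OC)c2)cc1O` gives 310 nM.
Compound 2 `COc1ccc(CN(C(=O)CBr)c2cc(OC)c(OC)c(OC)c2)cc1O` gives 68 nM.

Compound 2 stands at the lower of these two numbers, the stronger inhibitor, set apart from compound 1 by a 4.6-fold lower number from compound 1 to compound 2 (0.66 log units; beyond the scatter). Compound 3 `C=CC(=O)N(Cc1ccc(OC)c(O)c1)c1cc(OC)c(OC)c(OC)c1` has not been measured; it differs from compound 2 by vinyl in place of bromomethyl on a carbonyl carbon. Among the measured compounds shown here, the one measured step also swapped a group on that chain carbon and was modest, but no measured pair replaces it with vinyl, so it bears only loosely here. A modest shift in either direction in this assay is plausible. Compound 3 is expected to come in at 150 nM, within 40 nM to 600 nM. That estimate means a step of a 2.2-fold higher number from compound 2 to compound 3 (0.34 log units; beyond the scatter).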

Compound 3, half-maximal inhibitory concentration: 98 nM
Estimate against measurement, compound 3: 1.5-fold (0.18 log units) above; the measured number falls inside the stated range.
By their numbers in this assay, from the lowest: compounds 2 and 3 (each within the scatter of the next); then compound 1.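

In this assay, vinyl in place of bromomethyl on a carbonyl carbon gives a step within the scatter (a 1.4-fold higher number from compound 2 to compound 3 (0.16 log units; within the scatter)), so bromine is not needed at this position for a number of this size. The group carrying selenium and nitrile now gives a higher number than two different replacements rather than one (a 3.2-fold lower number from compound 1 to compound 3 (0.50 log units; beyond the scatter)). From the compounds shown here alone, how a longer chain or an amine on that carbonyl carbon would compare stays open. Nothing on hand explains these numbers.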